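This account rests on a few compounds, and the source may have more. Where it says the series, first, only, none or still open, it means among the compounds named here.

Measured in an assay on isolated protein for inhibition of Indoleamine 2,3-dioxygenase 1 (Homo sapiens); a lower number here means a stronger inhibitor, a higher number a weaker inhibitor:
compound 1 `OCc1cn(CCNc2nonc2/C(=N/O)Nc2ccc(F)c(Br)c2)nn1` gives 77 nM
compound 2 `CC(C)(C)c1cn(CCNc2nonc2/C(=N/O)Nc2ccc(F)c(Br)c2)nn1` gives 132 nM
compound 3 `CCC(C)(O)c1cn(CCNc2nonc2/C(=N/O)Nc2ccc(F)c(Br)c2)nn1` gives 53 nM

Compound 3 has the lowest number of the three, but only its gap to compound 2 lies beyond the scatter: a 2.5-fold lower number from compound 2 to compound 3 (0.40 log units; beyond the scatter), whereas a 1.5-fold lower number from compound 1 to compound 3 (0.16 log units; within the scatter). All three compounds share one core and differ only in the group on the same aromatic carbon of the shared five-membered ring.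

Compound 4 `CC(OCCO)c1cn(CCNc2nonc2/C(=N/O)Nc2ccc(F)c(Br)c2)nn1` carries 1-(2-hydroxyethoxy)ethyl in place of 1-hydroxy-1-methylpropyl on an aromatic carbon. This is once more a swap of the group on that carbon, the place where every measured step falls: a 1.7-fold higher number from compound 1 to compound 2 (0.23 log units; within the scatter), a 1.5-fold lower number from compound 1 to compound 3 (0.16 log units; within the scatter) and a 2.5-fold lower number from compound 2 to compound 3 (0.40 log units; beyond the scatter), none larger than modest. The expected step in this assay is therefore a 1.2-fold higher number from compound 3 to compound 4 (0.09 log units; within the scatter), not beyond the scatter. Compound 4 is estimated at 65 nM, within 30 nM to 150 nM.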

Compound 4, half-maximal inhibitory concentration: 134 nM
Compound 4: middle estimate off by 2.1-fold (0.31 log units), on the low side; the range from low to high includes it.
By their numbers in this assay, from the lowest: compounds 3, 1, 2 and 4 (each within the scatter of the next, the first and the last beyond it).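

At this carbon, a hydroxyl in the group does not by itself keep the number low: a 2.5-fold higher number from compound 3 to compound 4 (0.40 log units; beyond the scatter) is a step beyond the scatter between two hydroxyl-bearing groups. The other two steps, a 1.0-fold higher number from compound 2 to compound 4 (0.01 log units; within the scatter) and a 1.7-fold higher number from compound 1 to compound 4 (0.24 log units; within the scatter), both stay within the scatter, so compound 4 does not separate from compound 2, whose tert-butyl has no hydroxyl. No measured evidence bears on the origin of the step from compound 3.

Open, as far as these compounds go, is whether an amine or a carboxylic acid at the end of the 1-(2-hydroxyethoxy)ethyl chain would shift the number. A simple 1-methoxyethyl group would test whether the hydroxyl on that chain matters at all.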